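Propylamide and ethylamide pyridyl ethers: methoxy versus chloro

The source may report more compounds than this note shows. Statements on the series, on what has been measured and on what is new or still open speak of the compounds shown alone.

Measured so far:
compound 1 `CCNC(=O)c1cc(Oc2ccc(NC(=O)c3cc4cccnc4n(-c4ccc(OC)cc4)c3=O)cc2)ccn1`: 3350 nM
compound 2 `CCCNC(=O)c1cc(Oc2ccc(NC(=O)c3cc4cccnc4n(-c4ccc(Cl)cc4)c3=O)cc2)ccn1`: 390 nM

In a functional assay on HT-29 cells (Homo sapiens) for antiproliferative activity, read by MTT assay, with a stated time of 72 h (a lower number here means a stronger inhibitor, a higher number a weaker inhibitor), compound 2 gives the lowest of the two numbers; compound 1 sits well beyond the scatter above it, but the two differ in more than one place, so no single step can be read from them. Compound 3 `CCCNC(=O)c1cc(Oc2ccc(NC(=O)c3cc4cccnc4n(-c4ccc(OC)cc4)c3=O)cc2)ccn1` carries the change (methoxy in place of chloro on an aromatic carbon), on an aromatic carbon of a six-membered aromatic ring of carbon only, para to a large group. Compound 3 is expected to lose potency because compound 1, which carries the same methoxy, gives 3350 nM, though compound 1 also differs in the amide chain, so the size is uncertain. The step of a 3.8-fold higher number from compound 2 to compound 3 (0.59 log units; beyond the scatter) is the estimate, beyond the scatter. Compound 3 is estimated at 1500 nM, range 500 nM to 4500 nM.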

Compound 3, half-maximal inhibitory concentration: 1560 nM
For compound 3 the middle estimate is 1.0-fold (0.02 log units) below the measured one, and the stated range covers the measured number.
By their numbers in this assay, from the lowest: compound 2; then compound 3; then compound 1.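

In this assay, the change from 4-chlorophenyl to 4-methoxyphenyl can now be read alone, with the propylamide held constant: methoxy in place of chloro gives a 4.0-fold higher number from compound 2 to compound 3 (0.60 log units; beyond the scatter). With methoxy held constant, the amide chain can also be read alone, and the propylamide in place of the ethylamide gives a 2.1-fold lower number from compound 1 to compound 3 (0.33 log units; beyond the scatter). No measurement on hand gives a reason for either step. From the compounds shown here alone, it remains open how fluoro or trifluoromethyl would read at this place on the ring, and whether a butyl chain on the amide would extend the second step.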